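Swapping the aryl group on the shared core

A few compounds are considered here, and "the series" means these few. Any claim that something is new, unique, unknown or untested is made for them only; others in the source may bear on it.

The measure used here is a functional assay on BGC-823 cells (Homo sapiens) for antiproliferative activity, read by MTT assay, tested at 1 uM; a higher number here means a stronger effect of the compound at the concentration tested, a lower number a weaker effect. Compound 1 `COc1cc(C2=NN(C(C)=O)C(c3cc(Cl)cc(Cl)c3)O2)cc(OC)c1OC` gives 0% in this assay. Within the data shown here, compound 2 `COc1cc(C2=NN(C(C)=O)C(c3ccccc3C(F)(F)F)O2)cc(OC)c1OC` gives 31.8%, the highest of the two numbers so far; its nearest neighbour is compound 1, whose value lies lower by more than the usual scatter. Compound 3 `COc1cc(C2=NN(C(C)=O)C(c3ccc(Cl)c(Cl)c3)O2)cc(OC)c1OC` has not yet been measured. It differs from compound 2 in one place: 3,4-dichlorophenyl in place of 2-(trifluoromethyl)phenyl on a saturated ring carbon. Among the measured compounds shown here, the only measured step that bears on this change is a number 31.8 percentage points higher from compound 1 to compound 2 (beyond the scatter), a large rise obtained when a dichlorophenyl gave way to the 2-(trifluoromethyl)phenyl. For the measured compounds named here, compound 3 moves back to a dichlorophenyl, though with the two chlorines arranged as 3,4-dichlorophenyl rather than 3,5-dichlorophenyl, and that arrangement has no measured precedent, so the size of the reversal is uncertain. A downward step is therefore expected, estimated as a number 21.8 percentage points lower from compound 2 to compound 3 (beyond the scatter). For compound 3 the estimated inhibition is 10%, with a range from 0% to 30%.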

Compound 3, a percentage reported as inhibition, at one concentration (the size of the read-out at that concentration, not a potency): -0.8%
Beside the measured number, compound 3's estimate is 10.8 percentage points above it; the measured number lies below the stated range.
By their numbers in this assay, from the lowest: compounds 3 and 1 (each within the scatter of the next); then compound 2.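

In this assay, replacing the 2-(trifluoromethyl)phenyl with a 3,4-dichlorophenyl on this saturated ring carbon gives a number 32.6 percentage points lower from compound 2 to compound 3 (beyond the scatter) and removes the gain seen with compound 2. Changing 3,5-dichlorophenyl to 3,4-dichlorophenyl gives a number 0.8 percentage points lower from compound 1 to compound 3 (within the scatter) and so makes no readable difference, which means that for these two compounds the arrangement of the two chlorines does not separate them at this position, while compound 2 remains above both by more than the scatter. Nothing measured here explains why the two dichlorophenyl compounds sit so far below compound 2.

Compound 2 differs from both dichlorophenyl compounds in the kind of group on the phenyl ring, in how many groups it carries and in where they sit, so these three compounds cannot show which of those differences matters. Going by these compounds, it also remains open how this position would respond to an unsubstituted phenyl, a phenyl with a single chlorine, a phenyl with a methoxy group or a trifluoromethyl group placed elsewhere on the phenyl ring.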